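A Six-Membered Ring Enters at the Position of the Imidazole

The source may hold more compounds than are shown below. What is called first, only, known or untested is meant among the compounds shown, and "the series" means these compounds.

Compound 1 `Cc1cc(OC(C)(C)C)c(S(C)(=O)=O)cc1C(=O)N=C(N)N` gives 9.4 nM in a functional assay for inhibition of sodium/hydrogen exchanger (Oryctolagus cuniculus); on this read-out lower numbers stand for stronger inhibition and higher numbers for weaker inhibition.
Compound 2 `Cc1cc(Oc2ccccc2Cl)c(S(C)(=O)=O)cc1C(=O)N=C(N)N` gives 14 nM.
Compound 3 `Cc1cn(-c2cc(C)c(C(=O)N=C(N)N)cc2S(C)(=O)=O)cn1` gives 28 nM.

Compound 3 stands at the highest number of the three: toward compound 2 the change is a 2.0-fold higher number from compound 2 to compound 3 (0.30 log units; within the scatter), and toward compound 1 it is a 3.0-fold higher number from compound 1 to compound 3 (0.47 log units; beyond the scatter). Compound 4 `Cc1cc(-n2ccc(=O)cc2)c(S(C)(=O)=O)cc1C(=O)N=C(N)N` differs from compound 3 by a group of 7 heavy atoms (5 carbon, 1 nitrogen, 1 oxygen; one six-membered aromatic ring with 1 hetero atom) in place of a group of 6 heavy atoms (4 carbon, 2 nitrogen; one five-membered aromatic ring with 2 hetero atoms), on an aromatic carbon. Going by the values given here, the steps that bear on this position, a 1.5-fold higher number from compound 1 to compound 2 (0.17 log units; within the scatter) and a 3.0-fold higher number from compound 1 to compound 3 (0.47 log units; beyond the scatter), show that exchanges of the group on this aromatic carbon have moved this assay little, so only a small step, if any, is expected for compound 4, in no clear direction. The expected step is a 1.1-fold higher number from compound 3 to compound 4 (0.03 log units; within the scatter). Compound 4 is therefore estimated at 30 nM, with a range from 10 nM to 90 nM.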

Compound 4, half-maximal inhibitory concentration: 75 nM
Compound 4: middle estimate off by 2.5-fold (0.40 log units), on the low side, within the range that was stated.
By their numbers in this assay, from the lowest: compounds 1, 2 and 3 (each within the scatter of the next, the first and the last beyond it); then compound 4.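

In this assay, this aromatic carbon proved less tolerant than the earlier exchanges suggested: the six-membered ring gives a 2.7-fold higher number from compound 3 to compound 4 (0.43 log units; beyond the scatter), a modest step but one beyond the scatter. The gap is larger against the oxygen-linked groups, at a 5.4-fold higher number from compound 2 to compound 4 (0.73 log units; beyond the scatter) and an 8.0-fold higher number from compound 1 to compound 4 (0.90 log units; beyond the scatter), which leaves compound 4 with the highest number of the four. Nothing available here accounts for this loss. As far as these compounds go, whether a simple amine or a carboxylic acid on this aromatic carbon would stay near compound 1 or rise toward compound 4 remains open.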